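Shifting a Bromine Atom on the Shared Core

This account rests on a few compounds, and the source may have more. Where it says the series, first, only, none or still open, it means among the compounds named here.

Compound 2 `O=C1/C(=C/c2ccccc2Br)NS(=O)(=O)c2ccccc21` was tested in an assay for inhibition of alkaline phosphatase, tissue-nonspecific isozyme (Homo sapiens), read by spectrophotometry, with stated times of 10 min and 20 min; on this read-out higher numbers stand for weaker inhibition and lower numbers for stronger inhibition. In this assay compound 2 gives only a limit, > 200000 nM, not a number. Compound 1 `COc1cccc(/C=C2\NS(=O)(=O)c3ccccc3C2=O)c1` likewise gives only a limit in this assay, > 200000 nM. Both values sit at the limit of > 200000 nM in this assay, at which 2 of the 2 values shown sit, so compound 2 stands no differently from compound 1 on the numbers shown. Compound 3 `O=C1/C(=C/c2cccc(Br)c2)NS(=O)(=O)c2ccccc21` keeps the same atoms but differs in one place: 3-bromophenyl in place of 2-bromophenyl on a double-bonded chain carbon bound to a double-bonded ring carbon. For the measured compounds named here, no measured step of this kind exists here. The expected step of a number no higher from compound 2 to compound 3 (the limit leaves the size open) is therefore essentially none beyond the usual scatter. Compound 3 is estimated at 200000 nM, with a likely range from 50000 nM to 800000 nM, most probably reported again as a limit.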

Compound 3, half-maximal inhibitory concentration: > 200000 nM
Compound 3: no number, only a limit (the forecaster's own chance of this, stated with the estimate: 80%); the middle value sits exactly at the limit.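

No step can be read from compound 1 or compound 2 to compound 3, since each gives only a limit and not a number: the limit of > 200000 nM in this assay, at which 3 of the 3 values shown sit.

The compounds shown leave open how strongly any of them inhibits in this assay, and whether 3-bromophenyl and 2-bromophenyl differ at all.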